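Notes on a fluoroalkenyl series and its cytotoxicity limits

A few compounds are considered here, and "the series" means these few. Any claim that something is new, unique, unknown or untested is made for them only; others in the source may bear on it.

Compound 1, `[O-][S+](CCC(F)=C(F)F)c1ncc(-c2ccncc2)s1`, in a functional assay on SH-SY5Y cells (Homo sapiens) for cytotoxicity, read by MTT assay, with a stated time of 48 h (a higher number here means a weaker inhibitor, a lower number a stronger inhibitor), gives > 120000 nM, which is a limit of the assay.
Compound 2, `FC(F)=C(F)CCSc1nccs1`, in this assay gives > 120000 nM, again a limit.
Compound 3, `FC(F)=C(F)CCSc1ncc(-c2ccncc2)s1`, in this assay gives > 120000 nM, also a limit.

All three measured values sit at the same limit, as the evidence shows (the limit of > 120000 nM in this assay, at which 3 of the 3 values shown sit). The change from compound 3 to compound 2 is hydrogen in place of pyridin-4-yl on an aromatic carbon and yields a step that the two limits leave unreadable from compound 3 to compound 2. The difference between the cores of compound 1 and compound 3 is not broken down here.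

Compound 4, `[O-][S+](CCC(F)=C(F)F)c1nccs1`, remains to be measured in this assay. Its change from compound 1 is hydrogen in place of pyridin-4-yl on an aromatic carbon. This is the same kind of change as that from compound 3 to compound 2, though the places differ: in compound 1 the ring atom bears a group of 9 heavy atoms, in compound 3 a group of 8 heavy atoms.

Because the only shown step of this kind, a step that the two limits leave unreadable from compound 3 to compound 2, is unreadable between limits, and because all values rest at the limit (the limit of > 120000 nM in this assay, at which 3 of the 3 values shown sit), compound 4 is expected to show a step that the limit leaves unreadable from compound 1 to compound 4. The estimate for compound 4 in this assay is 200000 nM, with a range of 100000 nM to 500000 nM, and a further limit rather than a number is expected.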

Compound 4, half-maximal inhibitory concentration: > 120000 nM
Compound 4 ended at the assay's limit; the forecaster's own chance of this, stated with the estimate: 90%; the middle value lies beyond the limit too.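

No step can be read from compound 1 to compound 4, since both compounds rest at a limit of this assay and not at a number: the limit of > 120000 nM in this assay, at which 4 of the 4 values shown sit.

The compounds shown leave open whether hydrogen in place of pyridin-4-yl, or the difference between the cores of compound 1 and compound 3, changes cytotoxicity at all in this assay.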